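The compounds below may be only part of what the source reports. "The series", "measured", "known", "first", "only" and "open" are said of these compounds alone.

Compound 1 `CN1CCN(CCCCCCn2c3c(c4ccccc42)C(=O)c2c[n+]([O-])c4ccccc4c2C3=O)CC1` is a member of a small set built on one shared core, differing only in the group carried on the aromatic nitrogen. In a toxicity assay on HEK-293T cells (Homo sapiens) for cytotoxicity, read by MTT assay, with a stated time of 72 h (a higher number here means a weaker inhibitor, a lower number a stronger inhibitor), compound 1 gives 5800 nM. Compound 2 `O=C1c2c[n+]([O-])c3ccccc3c2C(=O)c2c1c1ccccc1n2Cc1cn([C@H]2C[C@H](O)[C@@H](CO)O2)nn1` gives 3600 nM and compound 3 `CC1(C)OC[C@@H](Cn2cc(Cn3c4c(c5ccccc53)C(=O)c3c[n+]([O-])c5ccccc5c3C4=O)nn2)O1` gives 6020 nM in this assay, so the number for compound 1 lies within the usual scatter of both neighbours. For the measured compounds named here, the one measured step, a 1.7-fold higher number from compound 2 to compound 3 (0.22 log units; within the scatter), also stays within scatter. Compound 4 `CN1CCN(CCCCn2c3c(c4ccccc42)C(=O)c2c[n+]([O-])c4ccccc4c2C3=O)CC1` differs from compound 1 by 4-methylpiperazin-1-yl in place of 2-(4-methylpiperazin-1-yl)ethyl on a saturated chain carbon, four bonds along the chain from an aromatic nitrogen. Going by the values given here, no measured step touches this chain, and the three known numbers barely move, so no step beyond the scatter is expected, namely a 1.0-fold higher number from compound 1 to compound 4 (0.01 log units; within the scatter). Compound 4 is therefore estimated at 6000 nM, between 2500 nM and 14000 nM.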

Compound 4, half-maximal inhibitory concentration: 100 nM
Estimate against measurement, compound 4: 60-fold (1.78 log units) above, and the stated range ends above it.
By their numbers in this assay, from the lowest: compound 4; then compounds 2, 1 and 3 (each within the scatter of the next).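

In this assay, putting 4-methylpiperazin-1-yl in place of 2-(4-methylpiperazin-1-yl)ethyl gives a 58-fold lower number from compound 1 to compound 4 (1.76 log units; beyond the scatter). The earlier compounds shown here, all within scatter of one another, gave no sign of this, yet a shorter chain alone, with the same ring at its end, moves the number far beyond the scatter. Nothing shown gives a reason for this step. The compounds shown leave open whether a chain of intermediate length, such as 3-(4-methylpiperazin-1-yl)propyl on the aromatic nitrogen, gives a number nearer compound 1 or compound 4. They also leave open whether a morpholine ring at the chain end behaves like the methylpiperazine.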